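A few compounds are considered here, and "the series" means these few. Any claim that something is new, unique, unknown or untested is made for them only; others in the source may bear on it.

Compound 1 `Cc1ccc(NC(=O)Nc2cc(-c3ccc(C(=O)O)cc3)ccc2Oc2ccccc2C(C)(C)C)cc1` gives > 1000 nM in an assay on HeLa cells for inhibition of Indoleamine 2,3-dioxygenase 1 (Homo sapiens), with stated times of 1 h and 18 h (a higher number here means a weaker inhibitor, a lower number a stronger inhibitor), which is a limit of the assay and not a number. Compound 2 `Cc1ccc(NC(=O)Nc2cc(-c3ccccc3C(=O)O)ccc2NC2CCCCC2)cc1` gives 504 nM in this assay.

Compound 2 therefore stands on the only number shown; the other value is the limit of > 1000 nM in this assay, at which 1 of the 2 values shown sits. Compound 3 `Cc1ccc(NC(=O)Nc2cc(-c3ccccc3C(=O)O)ccc2N2CCC[C@@H]3CCCC[C@@H]32)cc1` differs from compound 2 in one place: a group of 10 heavy atoms (9 carbon, 1 nitrogen; one six-membered non-aromatic ring of carbon only, one six-membered non-aromatic ring with 1 hetero atom) in place of a group of 7 heavy atoms (6 carbon, 1 nitrogen; one six-membered non-aromatic ring of carbon only), on an aromatic carbon. For the measured compounds named here, no measured step covers this change, so the two values shown give no direction for it. In this assay the expected step is a 1.3-fold higher number from compound 2 to compound 3 (0.11 log units; within the scatter), within the scatter or a modest weakening. Compound 3 is estimated at 650 nM, with a range from 200 nM to 2000 nM.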

Compound 3, half-maximal inhibitory concentration: 159 nM
For compound 3 the middle estimate is 4.1-fold (0.61 log units) above the measured one, and the stated range ends above it.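

At this position, on an aromatic carbon para to a 2-carboxyphenyl group, the larger two-ring group in place of cyclohexylamino gives a 3.2-fold lower number from compound 2 to compound 3 (0.50 log units; beyond the scatter) in this assay. The position therefore accepts this bulkier group, and the entering group's 0 hydrogen-bond donors show that a donor here is not needed for this number. Nothing measured here accounts for the gain.

From the compounds shown here alone, whether a simple piperidine or a morpholine here would keep the lower number stays open. So does the part played by the 2 defined stereocentres.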